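Cap group change from compound 2 to compound 3

A few compounds are considered here, and "the series" means these few. Any claim that something is new, unique, unknown or untested is made for them only; others in the source may bear on it.

Measured so far:
- compound 1, `COc1ccc(NS(=O)(=O)c2cccc(/C=C/C(=O)NO)c2)cc1`, in an assay for inhibition of protein deacetylase HDAC6 (Homo sapiens), read by fluorescence, with a stated time of 3 h (on this read-out higher numbers stand for an effect only at larger amounts of compound and lower numbers for an effect already at smaller amounts), compound 1 gives 36 nM
- compound 2, `O=C(/C=C/c1cccc(S(=O)(=O)N2CCN(c3ccccn3)CC2)c1)NO`, in this assay compound 2 gives 179 nM

Compound 2 stands at the higher of the two numbers recorded in this assay; its nearest neighbour is compound 1, and the gap between the two values lies beyond the scatter. Compound 1 and compound 2 differ in more than one place, so no single step can be read from that pair.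

Compound 3, `COc1ccccc1N1CCN(S(=O)(=O)c2cccc(/C=C/C(=O)NO)c2)CC1`, has not yet been measured. It differs from compound 2 in one place: 2-methoxyphenyl in place of pyridin-2-yl on an amine nitrogen in a ring. The aryl sulfonamide portion and the hydroxamate-bearing part of the shared core are unchanged.

Going by the values given here, no measured step of this kind is available in this assay. The change is confined to the group on the amine nitrogen in the ring, distant from the hydroxamate, and an expectation here can rest only on the value of compound 2 in this assay, which is 179 nM. The step from compound 2 to compound 3 is expected to be small, a 1.5-fold lower number from compound 2 to compound 3 (0.17 log units; within the scatter), at most a modest move to lower numbers and possibly none beyond the scatter. For compound 3 the estimate in this assay is 120 nM, with a range from 40 nM to 400 nM.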

Compound 3, concentration for half-maximal effect: 305 nM
For compound 3 the middle estimate is 2.5-fold (0.41 log units) below the measured one, within the range that was stated.
By their numbers in this assay, from the lowest: compound 1; then compounds 2 and 3 (each within the scatter of the next).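

In this assay, putting 2-methoxyphenyl in place of pyridin-2-yl on an amine nitrogen in a ring gives a 1.7-fold higher number from compound 2 to compound 3 (0.23 log units; within the scatter), so the two groups cannot be told apart at this position on this read-out. Going by these compounds alone, this is the first single-place step, and it shows that the hetero atom of the pyridin-2-yl ring can leave, with an all-carbon aromatic ring of 2-methoxyphenyl entering and the heavy-atom count going from 6 to 8, without a step beyond the scatter. Nothing available bears on why the two groups read alike in this assay.

Because both the ring hetero atom and the methoxy oxygen change in this one step, the compounds shown leave open how a plain phenyl group on the same nitrogen would read, and that group would separate the two changes. They also leave open whether an aromatic ring is needed there at all, which a cyclohexyl group, an acetyl group or a short alkyl chain on that nitrogen would test.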